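This account rests on a few compounds, and the source may have more. Where it says the series, first, only, none or still open, it means among the compounds named here.

Measured so far:
compound 1, `N#Cc1c(O)nc(SCc2nc3ccccc3[nH]2)nc1-c1ccccc1`: 7.81 nM
compound 2, `N#Cc1c(Cl)nc(SCc2nc3ccccc3[nH]2)nc1-c1ccccc1`: 8.62 nM

In a functional assay on GOTO cells (Homo sapiens) for cytotoxicity, read by MTT assay, with a stated time of 3 days (on this read-out lower numbers stand for stronger inhibition and higher numbers for weaker inhibition), compound 1 gives 7.81 nM, the lowest of the two numbers; the nearest is compound 2 with 8.62 nM, and the two sit within the scatter of each other. Compound 3, `N#Cc1c(NC(N)=O)nc(SCc2nc3ccccc3[nH]2)nc1-c1ccccc1`, follows from compound 1 by one change: ureido in place of hydroxy on an aromatic carbon. Within the data shown here, the only measured step that bears on this position is a 1.1-fold higher number from compound 1 to compound 2 (0.04 log units; within the scatter), where the same hydroxy was exchanged for chloro and the number did not move beyond the scatter. Among the measured compounds shown here, no measured compound carries a ureido group, so the size of a larger exchange at this carbon is untested, and the range is kept wide on both sides. On this footing compound 3 is expected to stay close to compound 1 in this assay, with no step beyond the scatter. Compound 3 is estimated at 10 nM, with a range from 4 nM to 30 nM. That estimate means an expected step of a 1.3-fold higher number from compound 1 to compound 3 (0.11 log units; within the scatter).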

Compound 3, half-maximal inhibitory concentration: 11.3 nM
Compound 3: middle estimate off by 1.1-fold (0.05 log units), on the low side; low and high end bracket the measured number.
By their numbers in this assay, from the lowest: compounds 1, 2 and 3 (each within the scatter of the next).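

In this assay, ureido in place of hydroxy gives a 1.4-fold higher number from compound 1 to compound 3 (0.16 log units; within the scatter), and ureido in place of chloro gives a 1.3-fold higher number from compound 2 to compound 3 (0.12 log units; within the scatter). The earlier pair covered only hydroxy and chloro on this aromatic carbon, whereas this result extends the series to a group of 4 heavy atoms with 2 hydrogen-bond donors, and the number still stays within the scatter of both earlier compounds. No measurement at hand accounts for this outcome.

From the compounds shown here alone, whether an amine, a carboxylic acid or a longer alkyl chain on this carbon would also stay within the scatter remains open. Also open, going by these compounds, is whether a change to the nitrile or the phenyl group of the shared core would move the number beyond it.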